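Methyl-to-hydrogen change on two related fused cores

The source may hold more compounds than are shown below. What is called first, only, known or untested is meant among the compounds shown, and "the series" means these compounds.

Compound 1 `CCCc1nc(C)c2c(C)nn(C)c(=O)n12` and compound 2 `CCCc1nc(C)c2cnn(C)c(=O)n12` share a core. Compound 3 `Cc1nnc(S)n2cncc12` has a different core; the difference between the two cores is not broken down here. Compound 4 `Sc1nncc2cncn12` is the unmeasured partner of compound 3.

In a functional assay for inhibition, with Homo sapiens as the target (a lower number here means a stronger inhibitor, a higher number a weaker inhibitor), compound 1 gives only a limit of the assay, > 48000 nM. In this assay compound 2 gives 20000 nM. Compound 3 also gives only a limit in this assay, > 48000 nM. Two of the three values thus sit at the limit of > 48000 nM in this assay, at which 2 of the 3 values shown sit.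

The change from compound 1 to compound 2 is hydrogen in place of methyl on an aromatic carbon. In this assay it gave an at least 2.4-fold lower number from compound 1 to compound 2 (0.38 log units; beyond the scatter). The change from compound 3 to compound 4 is hydrogen in place of methyl on an aromatic carbon. It is the same kind of change, but the surroundings differ: in compound 1 the carbon is meta to a methyl group (1 heavy atom) and para to a group of 1 heavy atom, whereas in compound 3 it is para to a sulfanyl group (1 heavy atom).

By analogy, the step from compound 3 to compound 4 is expected to be about an at least 1.2-fold lower number from compound 3 to compound 4 (0.07 log units; that floor lies within the scatter). From the compounds shown here alone, this rests on an at least 2.4-fold lower number from compound 1 to compound 2 (0.38 log units; beyond the scatter), with the caveat that the starting value of compound 3 is a limit, so the true starting point is unknown and compound 4 may itself come back as a limit.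

Compound 4 is expected near 40000 nM in this assay, estimated between 15000 nM and 150000 nM.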

Compound 4, half-maximal inhibitory concentration: > 48000 nM
Compound 4 ended at the assay's limit (the forecaster's own chance of this, stated with the estimate: 55%); middle value at least 1.2-fold (0.07 log units) away from the limit.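

Compound 4 gives > 48000 nM in this assay as a limit of the assay. Going by these compounds alone, compound 3 also stands at a limit, so no step between compound 3 and compound 4 can be read, because both values sit at the same limit: the limit of > 48000 nM in this assay, at which 3 of the 4 values shown sit.

From the compounds shown here alone, whether hydrogen in place of methyl on an aromatic carbon lowers the number on the core of compound 3, as it does on the core of compound 1, stays open.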